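Chloro Position Swap on a Shared Anilino Core

A few compounds are considered here, and "the series" means these few. Any claim that something is new, unique, unknown or untested is made for them only; others in the source may bear on it.

Compound 1 `Cc1nnc(-c2cc(Cl)ccc2Nc2ncnc3[nH]ccc23)[nH]1`: 171 nM
Compound 2 `Cc1nnc(-c2ccccc2Nc2ncnc3[nH]ccc23)[nH]1`: 151 nM
Compound 3 `Clc1c[nH]c2ncnc(N3CCc4[nH]cnc4C3)c12`: 42 nM

Of the compounds shown here, three have been measured in an assay on isolated protein for inhibition of RAC-alpha serine/threonine-protein kinase (Homo sapiens); a lower number here means a stronger inhibitor, a higher number a weaker inhibitor. Compound 2 stands second highest of the three numbers; its nearest neighbour is compound 1, and the step of a 1.1-fold lower number from compound 1 to compound 2 (0.05 log units; within the scatter) lies within the scatter. The furthest is compound 3, which gives 42 nM, a number well below that of compound 2 and beyond the scatter.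

Compound 4 `Cc1nnc(-c2ccc(Cl)cc2Nc2ncnc3[nH]ccc23)[nH]1` is not yet measured. It differs from compound 2 by chloro in place of hydrogen on an aromatic carbon. Among the compounds with values here, the only measured step that bears on this change is a 1.1-fold lower number from compound 1 to compound 2 (0.05 log units; within the scatter), in which a chloro on the same ring was removed from a different position and the number hardly moved. Compound 3 carries its chloro on another part of its structure and offers no direct guide.

On that basis, adding a chloro para to the 5-methyl-4H-1,2,4-triazol-3-yl group is expected to give no step beyond the scatter, with the estimated change a 1.0-fold lower number from compound 2 to compound 4 (0.00 log units; within the scatter). Compound 4 is therefore expected to give about 150 nM in this assay, within a range of 70 nM to 330 nM.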

Compound 4, half-maximal inhibitory concentration: > 10000 nM
Compound 4 ended at the assay's limit; the forecaster's own chance of this, stated with the estimate: 2%; middle value at least 66-fold (1.82 log units) from the limit.
By their numbers in this assay, from the lowest: compound 3; then compounds 2 and 1 (each within the scatter of the next). At a limit, above all of these: compound 4.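

Adding a single chloro on an aromatic carbon, para to a 5-methyl-4H-1,2,4-triazol-3-yl group and meta to a large group, gives an at least 66-fold higher number from compound 2 to compound 4 (1.82 log units; beyond the scatter) in this assay, whereas the earlier step on the same ring was a 1.1-fold lower number from compound 1 to compound 2 (0.05 log units; within the scatter). The value of compound 4, > 10000 nM, is a limit of the assay and not a number: the limit of > 10000 nM in this assay, at which 1 of the 4 values shown sits. For these compounds, then, the effect of a chloro on this ring depends on where it sits, and one heavy atom in place of hydrogen at this position is enough to take the series to that limit.

The compounds shown leave open whether the loss belongs to chloro itself or to any group at this position, and a fluoro or a methoxy on the same aromatic carbon would bear on that. They also leave open why this position differs so sharply from the chloro position in compound 1, as nothing shown here measures a cause.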